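The source may hold more compounds than are shown below. What is called first, only, known or untested is meant among the compounds shown, and "the series" means these compounds.

In a functional assay on MCF7 cells (Homo sapiens) for antiproliferative activity (on this read-out lower numbers stand for stronger inhibition and higher numbers for weaker inhibition), compound 1 `CC(C)=CCc1cc(C(=O)Nc2cc3ccc(OCCC4CCCCN4)c(C)c3oc2=O)ccc1O` gives 710 nM and compound 2 `CC(C)=CCc1cc(C(=O)Nc2cc3ccc(OCCCN(C(C)C)C(C)C)c(C)c3oc2=O)ccc1O` gives 1310 nM as its reading, which places compound 2 within the scatter of compound 1. Compound 3 `CC(C)=CCc1cc(C(=O)Nc2cc3ccc(OCCCNCCO)c(C)c3oc2=O)ccc1O` differs from compound 2 by (2-hydroxyethyl)amino in place of diisopropylamino on a saturated chain carbon, three bonds along the chain from an oxygen on an aromatic ring in that (2-hydroxyethyl)amino stands in place of diisopropylamino on a saturated chain carbon, three bonds along the chain from an oxygen on an aromatic ring. Going by the values given here, the one measured step bearing on this is a 1.8-fold higher number from compound 1 to compound 2 (0.27 log units; within the scatter) and it stays small. The change in this assay is therefore expected to be a 1.1-fold higher number from compound 2 to compound 3 (0.06 log units; within the scatter) with nothing beyond the scatter foreseen. Compound 3 is estimated at 1500 nM with an expected range from 500 nM to 4500 nM on this read-out.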

Compound 3, half-maximal inhibitory concentration: 1560 nM
Beside the measured number, compound 3's estimate is 1.0-fold (0.02 log units) below it; low and high end bracket the measured number.
By their numbers in this assay, from the lowest: compounds 1, 2 and 3 (each within the scatter of the next, the first and the last beyond it).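

In this assay, the step to (2-hydroxyethyl)amino on this saturated chain carbon (a 1.2-fold higher number from compound 2 to compound 3 (0.08 log units; within the scatter)) shows that the position takes a group with fewer heavy atoms and more hydrogen-bond donors than diisopropylamino without leaving the scatter. Measured against the piperidin-2-yl of compound 1, the same group gives the first gap here beyond the scatter, though a modest one (a 2.2-fold higher number from compound 1 to compound 3 (0.34 log units; beyond the scatter)). Nothing available explains either step. From the compounds shown here alone, whether a carboxylic acid or a morpholine ring at the end of this chain would read differently stays open, as does the effect of a longer chain.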